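Two dimethylphenyl isomers in the series

The source may report more compounds than this note shows. Statements on the series, on what has been measured and on what is new or still open speak of the compounds shown alone.

In a functional assay on KBVIN cells (Homo sapiens) for antiproliferative activity, read by sulforhodamine B assay, with a stated time of 3 days (on this read-out lower numbers stand for an effect already at smaller amounts and higher numbers for an effect only at larger amounts of compound), compound 1 (`CCC1=C(O)c2c(oc(-c3ccc(OC)c(C)c3)cc2=O)C(CC)(CC)C1=O`) gives 0.1 uM, compound 2 (`CCC1=C(O)c2c(oc(-c3ccc(OC)c(Cl)c3)cc2=O)C(CC)(CC)C1=O`) gives 1.37 uM and compound 3 (`CCC1=C(O)c2c(oc(-c3cccc(C)c3C)cc2=O)C(CC)(CC)C1=O`) gives 0.85 uM. Two steps fix the standing of the last: a 1.6-fold lower number from compound 2 to compound 3 (0.21 log units; within the scatter), within the scatter, and an 8.5-fold higher number from compound 1 to compound 3 (0.93 log units; beyond the scatter), beyond it. Compound 4 (`CCC1=C(O)c2c(oc(-c3cc(C)cc(C)c3)cc2=O)C(CC)(CC)C1=O`) carries 3,5-dimethylphenyl in place of 2,3-dimethylphenyl on an aromatic carbon. Those two steps are the nearest guides, since both replace the whole aryl group. Neither isolates a shift of the methyl groups, so direction remains weakly supported. The expected size is a 1.4-fold lower number from compound 3 to compound 4 (0.15 log units; within the scatter), which would stay within the scatter. For compound 4 the estimated value is 0.6 uM, with an expected range of 0.2 uM to 1.8 uM.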

Compound 4, concentration for half-maximal effect: 0.45 uM
For compound 4 the middle estimate is 1.3-fold (0.12 log units) above the measured one, and the stated range covers the measured number.
By their numbers in this assay, from the lowest: compound 1; then compounds 4, 3 and 2 (each within the scatter of the next, the first and the last beyond it).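

Compound 3 and compound 4 have the same atoms joined differently, and the rearrangement of the two methyl groups gives a 1.9-fold lower number from compound 3 to compound 4 (0.28 log units; within the scatter) in this assay, so these isomers cannot be told apart. Only the 3,5-dimethylphenyl isomer separates from the 3-chloro-4-methoxyphenyl group, with a 3.0-fold lower number from compound 2 to compound 4 (0.48 log units; beyond the scatter), while a 4.5-fold higher number from compound 1 to compound 4 (0.65 log units; beyond the scatter) leaves compound 1 with the lowest number. No measured evidence accounts for these steps.

Still open, on these data alone, is whether an amine or an ethyl group in place of one methyl on the 3,5-dimethylphenyl ring would bring the number nearer that of compound 1.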